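Halogen swap on the benzylsulfanyl arm of a shared core

The compounds below may be only part of what the source reports. "The series", "measured", "known", "first", "only" and "open" are said of these compounds alone.

Of the compounds shown here, three built on one core have been tested in a functional assay on HGC-27 cells (Homo sapiens) for inhibition, read by MTT assay, with a stated time of 72 h; a lower number here means a stronger inhibitor, a higher number a weaker inhibitor. Compound 1 `CCc1cc(N2CC[C@@H](C)[C@@H](N(C)c3ncnc4[nH]ccc34)C2)n2ncnc2n1` carries no benzylsulfanyl arm, and in this assay compound 1 reaches only the limit of > 100000 nM, a limit rather than a number (the limit of > 100000 nM in this assay, at which 1 of the 3 values shown sits). Compound 2 `Cc1cc(N2CC[C@@H](C)[C@@H](N(C)c3ncnc4[nH]ccc34)C2)n2nc(SCc3cc(Cl)ccc3Cl)nc2n1` bears a (2,5-dichlorobenzyl)sulfanyl group, and in this assay compound 2 gives 19200 nM, the highest of the two numbers shown. Its nearest neighbour is compound 3 `Cc1cc(N2CC[C@@H](C)[C@@H](N(C)c3ncnc4[nH]ccc34)C2)n2nc(SCc3ccc(Cl)cc3)nc2n1`, which in this assay gives 18400 nM; the change gives a 1.0-fold lower number from compound 2 to compound 3 (0.02 log units; within the scatter).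

Compound 4 `Cc1cc(N2CC[C@@H](C)[C@@H](N(C)c3ncnc4[nH]ccc34)C2)n2nc(SCc3ccc(Br)cc3)nc2n1` is the unmeasured member. The difference from compound 2 is 4-bromophenyl in place of 2,5-dichlorophenyl on a saturated chain carbon bound to a sulfur. Among the compounds with values here, the only measured step that bears on it is the one from compound 2 to compound 3, where a single halogen on the phenyl ring replaced the two chlorines and the number barely moved. The change to compound 4 is of the same kind, with bromine rather than chlorine in the same position, so no movement beyond the scatter is expected: the estimated step is a 1.1-fold lower number from compound 2 to compound 4 (0.03 log units; within the scatter). Compound 4 is therefore estimated to give 18000 nM in this assay, with a range from 9000 nM to 36000 nM.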

Compound 4, half-maximal inhibitory concentration: 19500 nM
For compound 4 the middle estimate is 1.1-fold (0.03 log units) below the measured one, and the stated range covers the measured number.
By their numbers in this assay, from the lowest: compounds 3, 2 and 4 (each within the scatter of the next). At a limit, above all of these: compound 1.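

Read on its own, bromo in place of chloro on an aromatic carbon gives a 1.1-fold higher number from compound 3 to compound 4 (0.03 log units; within the scatter) in this assay and so leaves the number within the scatter. Set against the 2,5-dichlorophenyl group, the 4-bromophenyl group gives a 1.0-fold higher number from compound 2 to compound 4 (0.01 log units; within the scatter) on the same saturated chain carbon bound to a sulfur, so that a second change at this position, and one with a different halogen, now lies within the scatter, where the earlier compounds offered a single such step. What is given here offers no measured reason for this absence of movement among compounds 2, 3 and 4.

Going by these compounds, all of compounds 2, 3 and 4 keep at least one halogen on the phenyl ring, so what a methoxy group, a nitrile or a carboxylic acid on that ring would give at this position stays open. Also open, on these data alone, is whether a longer chain in place of the saturated chain carbon bound to a sulfur, or an amine on the ring, would move the number beyond the scatter in this assay at all.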